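The source may report more compounds than this note shows. Statements on the series, on what has been measured and on what is new or still open speak of the compounds shown alone.

Measured so far in a functional assay on A549 cells (Homo sapiens) for cytotoxicity, read by MTT assay, with a stated time of 24 h, tested at 80 uM; a higher number here means a weaker effect of the compound at the concentration tested, a lower number a stronger effect:

Compound 1, `CCCCCCCCCCCCOC(=O)CCC(=O)N1CCN(CCCOc2cc3c(Nc4ccc(F)c(Cl)c4)ncnc3cc2OC)CC1`: 2.3%
Compound 2, `CCCCCCCCCCCCCOC(=O)CCC(=O)N1CCN(CCCOc2cc3c(Nc4ccc(F)c(Cl)c4)ncnc3cc2OC)CC1`: 6.8%
Compound 3, `CCCCCCCCCCCCCCCCCOC(=O)CCC(=O)N1CCN(CCCOc2cc3c(Nc4ccc(F)c(Cl)c4)ncnc3cc2OC)CC1`: 83.2%

All three share one core and differ only in the length of the saturated chain attached through the oxygen next to the carbonyl group. Compound 1 and compound 2 sit close together, and the step of a number 4.5 percentage points higher from compound 1 to compound 2 (within the scatter) is within the scatter, so nothing can be said about an order between them. Compound 3 stands apart: the step of a number 80.9 percentage points higher from compound 1 to compound 3 (beyond the scatter) and the step of a number 76.4 percentage points higher from compound 2 to compound 3 (beyond the scatter) are both beyond the scatter and large, so compound 3 has the weakest effect of the three in this assay.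

Compound 4, `CCCCCCCCCCCCCCCCCCOC(=O)CCC(=O)N1CCN(CCCOc2cc3c(Nc4ccc(F)c(Cl)c4)ncnc3cc2OC)CC1`, has not yet been measured. It differs from compound 3 by methyl in place of hydrogen on a saturated chain carbon, ten or more bonds along the chain from an oxygen next to a carbonyl group. The same change, (methyl in place of hydrogen on a saturated chain carbon, ten or more bonds along the chain from an oxygen next to a carbonyl group), was already made once between measured compounds and gave the step of a number 4.5 percentage points higher from compound 1 to compound 2 (within the scatter), which is within the scatter. The core of compound 3 relative to compound 1 differs by pentyl in place of hydrogen on a saturated chain carbon, ten or more bonds along the chain from an oxygen next to a carbonyl group, so the change is applied here to a longer chain than where it was first seen.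

Given that the one observed instance of this change is within the scatter, the step of a number 3.8 percentage points higher from compound 3 to compound 4 (within the scatter) is expected to be small as well, and because compound 3 already gives 83.2% the room upward is limited. Compound 4 is estimated at 87% in this assay, with an expected range from 70% to 100%.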

Compound 4, a percentage reported as activity, at one concentration (the size of the read-out at that concentration, not a potency): 86.7%
For compound 4 the middle estimate is 0.3 percentage points above the measured one; the measured number falls inside the stated range.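

In this assay, methyl in place of hydrogen on a saturated chain carbon gives a number 3.5 percentage points higher from compound 3 to compound 4 (within the scatter), so the small size of this step carries over from the shorter chain to the longer one: the same change on two cores in this assay, a number 4.5 percentage points higher (within the scatter) from compound 1 to compound 2 and a number 3.5 percentage points higher (within the scatter) from compound 3 to compound 4, 1 percentage points apart, within the scatter of two such steps

Pentyl in place of hydrogen at the same kind of place gives a number 79.9 percentage points higher from compound 2 to compound 4 (beyond the scatter), and this large step also carries over: the same change on two cores in this assay, a number 80.9 percentage points higher (beyond the scatter) from compound 1 to compound 3 and a number 79.9 percentage points higher (beyond the scatter) from compound 2 to compound 4, 1 percentage points apart, within the scatter of two such steps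

Going by these compounds alone, this shows that steps of the same kind agree in this assay on these chains, but each comparison rests on only two cores that differ solely in chain length, while the hexyl step, a number 84.4 percentage points higher from compound 1 to compound 4 (beyond the scatter), has no counterpart here, so nothing shows that the change would carry over to a different core or to another assay.

Still open, as far as these compounds go, is where along the chain lengths from compound 2 to compound 3 the large step arises, and whether chains of intermediate length give intermediate values or fall with one of the two groups. Also open, from the compounds shown here alone, is how a longer chain, a branched chain, or a chain ending in an amine or a carboxylic acid would read in this assay.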